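Varying the Benzyl Aryl Group: From Compound 2 to Compound 3

The source may report more compounds than this note shows. Statements on the series, on what has been measured and on what is new or still open speak of the compounds shown alone.

Among the measured compounds shown here, compound 2 `Cc1cc(C(=O)O)nn1Cc1cc(Br)ccc1OCc1c(F)cccc1F` gives 14.8 nM in an assay on CHO-K1 cells for displacement of a labelled ligand from prostaglandin E2 receptor EP1 subtype (Homo sapiens) (on this read-out lower numbers stand for stronger inhibition and higher numbers for weaker inhibition), the higher of the two numbers measured so far; compound 1 `Cc1cc(C(=O)O)nn1Cc1cc(Br)ccc1OCc1ccc(F)cc1` gives 7.41 nM, and the step of a 2.0-fold higher number from compound 1 to compound 2 (0.30 log units; within the scatter) lies within the scatter. Compound 3 `Cc1cc(C(=O)O)nn1Cc1cc(Br)ccc1OCc1cccc(Br)c1` carries 3-bromophenyl in place of 2,6-difluorophenyl on a saturated chain carbon bound to an oxygen on an aromatic ring. For the measured compounds named here, the only measured step, from compound 1 to compound 2, also altered the aromatic ring on that saturated carbon and stayed within the scatter, so no shift beyond the scatter is expected for compound 3 in this assay. Compound 3 is therefore estimated at 12 nM, within 4 nM to 40 nM, an expected step of a 1.2-fold lower number from compound 2 to compound 3 (0.09 log units; within the scatter).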

Compound 3, half-maximal inhibitory concentration: 17.8 nM
Beside the measured number, compound 3's estimate is 1.5-fold (0.17 log units) below it, and the stated range covers the measured number.
By their numbers in this assay, from the lowest: compounds 1, 2 and 3 (each within the scatter of the next, the first and the last beyond it).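

In this assay, 3-bromophenyl in place of 2,6-difluorophenyl on the saturated chain carbon leaves the two groups inside the scatter of each other (a 1.2-fold higher number from compound 2 to compound 3 (0.08 log units; within the scatter)). Set against 4-fluorophenyl, however, 3-bromophenyl gives the first step at this position that lies beyond the scatter, though only a modest one (a 2.4-fold higher number from compound 1 to compound 3 (0.38 log units; beyond the scatter)). Nothing available bears on the reason for this result.

As far as these compounds go, what 3-fluorophenyl or 4-bromophenyl would give at this position stays open, and with it whether the identity of the halogen or its place on the ring carries that step. The reading for a phenyl ring bearing an amine is open as well.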